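Swapping 4-bromophenyl for 3-fluorophenyl on the extended urea

The source may hold more compounds than are shown below. What is called first, only, known or untested is meant among the compounds shown, and "the series" means these compounds.

Measured in a functional assay on L1210 cells (Mus musculus) for inhibition, read by MTT assay, with a stated time of 72 h; a lower number here means a stronger inhibitor, a higher number a weaker inhibitor:
Compound 1 `COc1cc(NC(C)CCCNC(=O)Nc2cccc(F)c2)c2ncccc2c1`: 19000 nM
Compound 2 `COc1cc(NC(C)CCCNC(=O)NNC(=O)Nc2ccc(Br)cc2)c2ncccc2c1`: 51000 nM

Compound 2 has the higher of the two numbers, which makes it the weaker inhibitor of the pair. Compound 3 `COc1cc(NC(C)CCCNC(=O)NNC(=O)Nc2cccc(F)c2)c2ncccc2c1` differs from compound 2 in one place: 3-fluorophenyl in place of 4-bromophenyl on an amide-type nitrogen. In words, 3-fluorophenyl stands in place of 4-bromophenyl on an amide-type nitrogen. Within the data shown here, only one measured step bears on this, a 2.7-fold higher number from compound 1 to compound 2 (0.43 log units; beyond the scatter). That modest step put ((4-bromophenyl)carbamoyl)amino in place of 3-fluorophenyl, so it covers more than the present swap, and the data cannot separate its parts. Since compound 3 regains the 3-fluorophenyl of compound 1, a small move to a lower number in this assay is expected, perhaps not beyond the scatter. The estimated step is a 1.5-fold lower number from compound 2 to compound 3 (0.16 log units; within the scatter). For compound 3 the estimated value is 35000 nM, with an expected range from 16000 nM to 75000 nM.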

Compound 3, half-maximal inhibitory concentration: 108000 nM
The estimate for compound 3 lay 3.1-fold (0.49 log units) below the measured number; the measured number lies above the stated range.
By their numbers in this assay, from the lowest: compound 1; then compound 2; then compound 3.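

In this assay, the aryl group on the extended urea is shown to matter: 3-fluorophenyl in place of 4-bromophenyl gives a 2.1-fold higher number from compound 2 to compound 3 (0.33 log units; beyond the scatter) and makes compound 3 the weakest inhibitor of the three. With 3-fluorophenyl held constant, the change to ((3-fluorophenyl)carbamoyl)amino gives a 5.7-fold higher number from compound 1 to compound 3 (0.75 log units; beyond the scatter) and so shows the effect of extending the urea without the change of aryl group that was mixed into the earlier step. Nothing available explains either step. The compounds shown leave open whether the difference between the two aryl groups comes from the halogen or from its place on the ring, which 4-fluorophenyl and 3-bromophenyl could help to separate. Going by these compounds, it also remains open how 4-bromophenyl would behave on the shorter urea of compound 1.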